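This account rests on a few compounds, and the source may have more. Where it says the series, first, only, none or still open, it means among the compounds named here.

Compound 1 `Cc1cc(-c2ccc3[nH]c(=O)nc(-c4ccccc4)c3c2)ccn1`: > 50000 nM
Compound 2 `O=c1nc(-c2ccccc2)c2cc(-c3ccc(F)cc3)ccc2[nH]1`: 50000 nM

In an ADME assay on L6 cells (Rattus norvegicus) for cytotoxicity, read by fluorescence and resazurin assay, with a stated time of 72 h (a lower number here means that less compound is needed, a higher number that more compound is needed for the effect), compound 1 gives > 50000 nM, which is a limit of the assay and not a number. Among the compounds with values here, compound 2 gives 50000 nM, the only true number available so far, so it has no numerical neighbour to be ranked against.

The next structure, compound 3 `O=c1nc(-c2ccccc2)c2cc(-c3cc[nH]n3)ccc2[nH]1`, has 1H-pyrazol-3-yl in place of 4-fluorophenyl on an aromatic carbon. The shared core and its phenyl group stay the same.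

Within the data shown here, only one measured step bears on this change, and it also alters the group at this same place. As far as these compounds go, it reads a number no higher from compound 1 to compound 2 (the limit leaves the size open), and its size stays unknown because of the limit of > 50000 nM in this assay, at which 1 of the 2 values shown sits. That step offers no sign of a large effect from changing this group, though it is thin evidence. In this assay, no step beyond the usual scatter is therefore expected, and a result reported only as a limit would be no surprise. The estimate corresponds to an expected 1.3-fold lower number from compound 2 to compound 3 (0.10 log units; within the scatter). For compound 3, the estimated value is 40000 nM, with an expected range of 15000 nM to 50000 nM.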

Compound 3, half-maximal effective concentration: > 50000 nM
Compound 3 ended at the assay's limit; the forecaster's own chance of this, stated with the estimate: 50%; middle value at least 1.2-fold (0.09 log units) from the limit.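

In this assay, putting 1H-pyrazol-3-yl, a five-membered aromatic ring with a hydrogen-bond donor, where 4-fluorophenyl stood gives a number no lower from compound 2 to compound 3 (the limit leaves the size open). Neither the size of this step nor the step between compounds 1 and 3 can be read, because the values of those two compounds are limits of the assay and not numbers: the limit of > 50000 nM in this assay, at which 2 of the 3 values shown sit. What this adds is a third, different aromatic group at this place on the shared core, and neither 1H-pyrazol-3-yl nor 2-methylpyridin-4-yl has brought a number lower than that of compound 2, so cytotoxicity in these cells has not yet appeared at lower concentrations with any of the three groups.

The compounds shown leave open whether a group of another kind at this place, such as an amine or a carboxylic acid, would bring the number down to a readable value. They also leave open how far compounds 1 and 3 lie beyond the limit, and whether a change to the phenyl group on the shared core would matter more than changes at this place.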